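The source may hold more compounds than are shown below. What is called first, only, known or untested is meant among the compounds shown, and "the series" means these compounds.

Measured in a functional assay on KBVIN cells (Homo sapiens) for antiproliferative activity, read by sulforhodamine B assay, with a stated time of 3 days; a lower number here means that less compound is needed, a higher number that more compound is needed for the effect:
Compound 1 `CCC1=C(O)c2c(oc(-c3ccc(C)cc3)cc2=O)C(CC)(CC)C1=O` gives 0.08 uM.
Compound 2 `CCC1=C(O)c2c(oc(-c3ccc(C(F)(F)F)cc3)cc2=O)C(CC)(CC)C1=O` gives 10.4 uM.
Compound 3 `CCOc1ccc(-c2cc(=O)c3c(o2)C(CC)(CC)C(=O)C(CC)=C3O)cc1` gives 7.54 uM.

Compound 3 stands second highest of the three numbers. Its nearest neighbour is compound 2: a 1.4-fold lower number from compound 2 to compound 3 (0.14 log units; within the scatter). Against compound 1 it is far off: a 94-fold higher number from compound 1 to compound 3 (1.97 log units; beyond the scatter). The other large step, a 130-fold higher number from compound 1 to compound 2 (2.11 log units; beyond the scatter), points the same way.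

Compound 4 `CCC1=C(O)c2c(oc(-c3cccc(F)c3)cc2=O)C(CC)(CC)C1=O` differs from compound 3 in one place: 3-fluorophenyl in place of 4-ethoxyphenyl on an aromatic carbon. For the measured compounds named here, no measured step matches this change. All three measured steps exchange one group for another at the same site, and none of them brings in fluorine. They show only that the methyl case, compound 1, runs far below the other two, while ethoxy and trifluoromethyl sit close together in this assay. The 3-fluorophenyl group is smaller than the 4-ethoxyphenyl group by the count given and carries no hydrogen-bond acceptor; whether that places compound 4 with compound 1 or with compounds 2 and 3 cannot be read from the numbers in hand.

Compound 4 is therefore expected to land between the two groups of numbers, with a wide range: the estimate is 1.5 uM, from 0.15 uM to 12 uM. This corresponds to an expected step of a 5.0-fold lower number from compound 3 to compound 4 (0.70 log units; beyond the scatter).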

Compound 4, concentration for half-maximal effect: 3.09 uM
Compound 4: middle estimate off by 2.1-fold (0.31 log units), on the low side; measured number inside the range.
By their numbers in this assay, from the lowest: compound 1; then compound 4; then compounds 3 and 2 (each within the scatter of the next).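

In this assay, the aromatic carbon next to the ring oxygen takes 3-fluorophenyl in place of 4-ethoxyphenyl with only a modest change (a 2.4-fold lower number from compound 3 to compound 4 (0.39 log units; beyond the scatter)). For the compounds shown here, this is the first group with fluorine as its only ring substituent and no hydrogen-bond acceptor, yet the step from the methyl case remains large (a 39-fold higher number from compound 1 to compound 4 (1.59 log units; beyond the scatter)). Among the four groups shown, the 4-methylphenyl of compound 1 thus remains alone at the low end, with all three other groups far above it, and no measurement available here bears on the cause of these steps.

It remains open whether the low number of compound 1 belongs to the methyl group itself or to its place on the phenyl ring, and no pair shown holds one group fixed while moving it around that ring. From the compounds shown here alone, how closely related groups such as 3-methylphenyl, 4-fluorophenyl, 4-ethylphenyl or 4-aminophenyl would compare with compound 1 in this assay also remains open.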